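Halogen Swap on the Naphthyl Ring and Hepatocyte Clearance

This account rests on a few compounds, and the source may have more. Where it says the series, first, only, none or still open, it means among the compounds named here.

Measured compounds:
compound 1, `COc1cc(N(CC2CC2)c2ccc(Cl)c3ccccc23)cnc1C(=O)[C@H]1C[C@@H]1C(=O)O`, 5 uL/min;
compound 2, `COc1cc(N(CC2CC2)c2ccc(Cl)c3ccccc23)cnc1C(=O)CCCC(=O)O`, 6.8 uL/min.

In an ADME assay on cells (Hepatocyte, Homo sapiens) for metabolic stability, read by LC-MS, with a stated time of 60 min, tested at 1 uM (on this read-out lower numbers stand for slow clearance and higher numbers for fast clearance), compound 1 gives 5 uL/min, the lowest of the two numbers. Among the compounds with values here, the only measured step, a 1.4-fold higher number from compound 1 to compound 2 (0.13 log units; within the scatter), concerns the acid-bearing chain and says nothing about the halogen. Compound 3, `COc1cc(N(CC2CC2)c2ccc(F)c3ccccc23)cnc1C(=O)[C@H]1C[C@@H]1C(=O)O`, differs from compound 1 by fluoro in place of chloro on an aromatic carbon. Within the data shown here, no measured step bears on this change, so the expectation rests on compound 1 alone, and no step beyond the scatter is anticipated. Compound 3 is therefore expected to give 4.5 uL/min, within 2 uL/min to 10 uL/min, an estimated step of a 1.1-fold lower number from compound 1 to compound 3 (0.05 log units; within the scatter).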

Compound 3, intrinsic clearance in a liver preparation (reported as CLH), per the amount of preparation that the assay uses: 5.4 uL/min
Compound 3: the middle estimate sits 1.2-fold (0.08 log units) below what was measured; low and high end bracket the measured number.
By their numbers in this assay, from the lowest: compounds 1, 3 and 2 (each within the scatter of the next).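

In this assay the swap of chloro for fluoro, on the aromatic carbon para to a large group, gives a 1.1-fold higher number from compound 1 to compound 3 (0.03 log units; within the scatter) and so does not tell the two halogens apart on this read-out. Within the data shown here, this is the first view of this position, since the earlier step concerned only the acid-bearing chain. No evidence is available on what lies behind this result.

As far as these compounds go, whether bromo, nitrile or plain hydrogen at this position would also stay within the scatter remains open. So does whether fluoro gives the same result alongside the 3-carboxypropyl chain.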